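The source may report more compounds than this note shows. Statements on the series, on what has been measured and on what is new or still open speak of the compounds shown alone.

Values measured in an in vitro ADME assay on microsomes from liver (Mus musculus) for pharmacokinetics, read by LC-MS, with a stated time of 10 min, tested at 1 uM; a lower number here means slower removal, a higher number faster removal of the compound:
Compound 1 `CN1C[C@H](C(=O)Nc2cccc(F)c2)[C@@H](c2ccc(/C=C/C(=O)Nc3ccccc3N)cc2)C1`: 56 mL/min/kg
Compound 2 `Cc1ccc(NC(=O)[C@H]2CN(C)C[C@@H]2c2ccc(/C=C/C(=O)Nc3ccccc3N)cc2)cn1`: 57 mL/min/kg
Compound 3 `CN1C[C@H](C(=O)Nc2ccccn2)[C@@H](c2ccc(/C=C/C(=O)Nc3ccccc3N)cc2)C1`: 40 mL/min/kg

At 40 mL/min/kg, compound 3 stands within the scatter of both of the other compounds. Compound 4 `CN1C[C@H](C(=O)Nc2ccc(Cl)cn2)[C@@H](c2ccc(/C=C/C(=O)Nc3ccccc3N)cc2)C1` keeps the shared core and turns the pyridin-2-yl of compound 3 into 5-chloropyridin-2-yl (chloro in place of hydrogen on an aromatic carbon). Among the measured compounds shown here, no measured step tests chloro in place of hydrogen directly. The nearest evidence comes from changes to the same amide substituent: a 1.4-fold lower number from compound 1 to compound 3 (0.15 log units; within the scatter), a 1.4-fold lower number from compound 2 to compound 3 (0.15 log units; within the scatter) and a 1.0-fold higher number from compound 1 to compound 2 (0.01 log units; within the scatter). All three stay within the scatter, so this part of the molecule has not yet shown a clear effect on clearance in this assay. A step beyond the scatter is therefore not expected here, and only a small move towards the values of compound 1 and compound 2 is anticipated. The estimated change is a 1.2-fold higher number from compound 3 to compound 4 (0.08 log units; within the scatter), which would remain within the scatter. Compound 4 is expected to give about 48 mL/min/kg, with an estimated range from 27 mL/min/kg to 82 mL/min/kg.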

Compound 4, clearance: 31 mL/min/kg
Estimate against measurement, compound 4: 1.5-fold (0.19 log units) above; measured number inside the range.
By their numbers in this assay, from the lowest: compounds 4, 3, 1 and 2 (each within the scatter of the next).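

In this assay, chloro in place of hydrogen on an aromatic carbon, two atoms from the ring nitrogen, is now tested directly and gives a 1.3-fold lower number from compound 3 to compound 4 (0.11 log units; within the scatter), so this position accepts a chlorine without a step beyond the scatter. The comparisons with the other two amide substituents, a 1.8-fold lower number from compound 2 to compound 4 (0.26 log units; within the scatter) and a 1.8-fold lower number from compound 1 to compound 4 (0.26 log units; within the scatter), also stay within the scatter, so across all four substituents this part of the molecule still shows no clear effect on clearance. No measurement shown here bears on the reason for these numbers.

On these data alone, it remains open whether an amine, a carboxylic acid or a methoxy group at this same place would bring a step beyond the scatter. As far as these compounds go, it is also open whether chloro on another carbon of the ring would give a similar number.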